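The source may report more compounds than this note shows. Statements on the series, on what has been measured and on what is new or still open speak of the compounds shown alone.

Measured in a toxicity assay on HEK-293T cells (Homo sapiens) for inhibition, read by MTT assay, with a stated time of 24 h; on this read-out lower numbers stand for higher toxicity in this test and higher numbers for lower toxicity in this test:
- Compound 1 `O=c1oc2ccccc2c(N2CCN(C(c3ccc(F)cc3)c3ccc(F)cc3)CC2)c1CO`: > 50000 nM, a limit.
- Compound 2 `O=c1oc2ccccc2c(N2CCN(c3ccccc3F)CC2)c1CO`: > 50000 nM, a limit.
- Compound 3 `O=c1oc2ccccc2c(N2CCN(C(c3ccccc3)c3ccc(Cl)cc3)CC2)c1CO`: > 50000 nM, a limit.

Compound 2 has no numerical value on this read-out, only a limit. It stands with the other two measured compounds, and the record for the series is the limit of > 50000 nM in this assay, at which 3 of the 3 values shown sit. Going by the values given here, no compound goes against this, but three compounds make a small set, and no measured step is available to scale from.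

Compound 4 `COc1ccc(N2CCN(c3c(CO)c(=O)oc4ccccc34)CC2)cc1` keeps the shared core and has 4-methoxyphenyl in place of 2-fluorophenyl on an amine nitrogen in a ring. Among the compounds with values here, no measured pair shows what such a change does in this assay.

The expected outcome is no change beyond the scatter, in either direction, and the most likely report is again a limit. The estimated size is a number no higher from compound 2 to compound 4 (the limit leaves the size open). For compound 4 the estimated value is 50000 nM, with an expected range from 20000 nM to 100000 nM.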

Compound 4, half-maximal cytotoxic concentration: > 50000 nM
Compound 4 ended at the assay's limit; the forecaster's own chance of this, stated with the estimate: 85%; the middle value lies on the limit itself.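

No step can be read from compound 2 to compound 4 in this assay: both results are limits, not numbers. The compounds shown leave open whether any change on the shared core would give a numerical value, with the series so far at one record: the limit of > 50000 nM in this assay, at which 4 of the 4 values shown sit.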